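Ketone head-group variation on an oleyl chain

The source may hold more compounds than are shown below. What is called first, only, known or untested is meant among the compounds shown, and "the series" means these compounds.

Measured so far:
compound 1 `CCCCCCCC/C=C\CCCCCCC(=O)c1ccccn1` — > 100000 nM
compound 2 `CCCCCCCC/C=C\CCCCCCC(=O)c1nc(-c2ccccc2)c(-c2ccccc2)o1` — > 100000 nM

In an assay on isolated protein for inhibition of Fatty-acid amide hydrolase 1 (Homo sapiens) (on this read-out higher numbers stand for weaker inhibition and lower numbers for stronger inhibition), compound 1 gives > 100000 nM, which is a limit of the assay and not a number. In this assay compound 2 likewise gives > 100000 nM, again a limit. For the measured compounds named here, both values sit at the same limit (the limit of > 100000 nM in this assay, at which 2 of the 2 values shown sit), so compound 1 cannot be ranked against compound 2 and no step between them is known.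

Compound 3 `CCCCCCCC/C=C\CCCCCCC(=O)c1nc2ncccc2o1` is not yet measured. It differs from compound 1 by a group of 9 heavy atoms (6 carbon, 2 nitrogen, 1 oxygen; one five-membered aromatic ring with 2 hetero atoms, one six-membered aromatic ring with 1 hetero atom) in place of a group of 6 heavy atoms (5 carbon, 1 nitrogen; one six-membered aromatic ring with 1 hetero atom), on a carbonyl carbon. Going by the values given here, no measured step resembles this change, so its size and direction are open; with both measured compounds at the limit, any real inhibition by compound 3 would appear as a step toward stronger inhibition, but a further limit is equally possible.

Compound 3 is expected at 5000 nM, within 20 nM to 200000 nM, which would mean an estimated step of an at least 20-fold lower number from compound 1 to compound 3 (1.30 log units; beyond the scatter).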

Compound 3, inhibition constant: 2.3 nM
The estimate for compound 3 lay 2200-fold (3.34 log units) above the measured number; the whole stated range lies above it.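

In this assay, the group on the carbonyl carbon separates no measurable inhibition from strong inhibition on the same oleyl chain: replacing pyridin-2-yl with the new two-ring group gives an at least 43000-fold lower number from compound 1 to compound 3 (4.63 log units; beyond the scatter). Compound 1 gives > 100000 nM, which is a limit and not a number, so the step has a lower bound only: the limit of > 100000 nM in this assay, at which 2 of the 3 values shown sit. The oleyl chain alone is not enough, as compound 1, compound 2 and compound 3 all carry it and only compound 3 gives a value that is a number.

The compounds shown do not separate the contribution of the five-membered ring from that of the nitrogen in the six-membered ring. On these data alone, it also remains open whether this potency survives a saturated or shorter chain, or a carboxylic acid or an amine on the six-membered ring.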